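The source may hold more compounds than are shown below. What is called first, only, known or untested is meant among the compounds shown, and "the series" means these compounds.

Measured so far in a functional assay on the whole organism with Rattus norvegicus as the target, at a dose of 20 mg/kg by the intraperitoneal route; a higher number here means more inhibition at the dose given (going by the name of the read-out), a lower number less inhibition:
- compound 1, `CCOc1ccccc1-c1nc(N)nc(N)n1`, gives -5%
- compound 2, `Nc1nc(N)nc(-c2cccc(SC(F)(F)F)c2)n1`, gives 87%
- compound 3, `Nc1nc(N)nc(-c2cc(Cl)ccc2F)n1`, gives 89%

Compound 1 stands lowest of the three numbers. Its nearest neighbour is compound 2, whose value lies far higher, beyond the usual scatter, and compound 3 lies higher still by a similar margin. The two compounds that share the core with compound 1 but carry other substituents on the carbon-only ring thus give far higher numbers in this assay than compound 1 does.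

Compound 4, `Nc1nc(N)nc(-c2ccccc2I)n1`, has not yet been measured. It differs from compound 1 in one place: iodo in place of ethoxy on an aromatic carbon. Among the measured compounds shown here, no measured pair in this set isolates that kind of change, so its size in this assay can only be judged from the spread between compound 1 and the others. Given that both other substituted analogues give far higher numbers than compound 1, the step from compound 1 to compound 4 is expected to be upward and beyond the scatter, though with wide uncertainty: the account estimates a number 60 percentage points higher from compound 1 to compound 4 (beyond the scatter). Compound 4 is accordingly expected to give about 55%, within a range from 0% to 95%.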

Compound 4, a percentage reported as inhibition, in the whole organism at one dose (the size of the read-out at that dose, not a potency): -7%
Beside the measured number, compound 4's estimate is 62 percentage points above it; the whole stated range lies above it.
By their numbers in this assay, from the lowest: compounds 4 and 1 (each within the scatter of the next); then compounds 2 and 3 (each within the scatter of the next).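

In this assay, iodo in place of ethoxy on an aromatic carbon, ortho to a group of 8 heavy atoms, gives a number 2 percentage points lower from compound 1 to compound 4 (within the scatter). Among the compounds shown here, this is the first pair that isolates a change at this position, and it shows that this exchange, in which the one hydrogen-bond acceptor of ethoxy leaves, does not move the number beyond the scatter. Nothing measured here offers an explanation for this result.

The compounds shown leave open whether an amine, a carboxylic acid or a longer chain on this same aromatic carbon would change the number in this assay. Steps from compound 1 or compound 4 to compound 2 or compound 3 cannot be read, as those compounds differ in more than one place.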